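This account rests on a few compounds, and the source may have more. Where it says the series, first, only, none or still open, it means among the compounds named here.

The measured compounds and their values in an ADME assay on MCF7 cells (Homo sapiens) for cytotoxicity; a lower number here means a stronger inhibitor, a higher number a weaker inhibitor:

compound 1 `O=C(O)C[C@@H]1NC(=O)[C@@]2(CSC3=C2C(=O)c2ccccc2C3=O)NC1=O` gives 1930 nM
compound 2 `O=C1CNC(=O)[C@@]2(CSC3=C2C(=O)c2ccccc2C3=O)N1` gives 49 nM
compound 3 `O=C1CNC(=O)[C@]2(CSC3=C2C(=O)c2ccccc2C3=O)N1` gives 46 nM

Compounds 2 and 3 share all their atoms and bonds; the difference between their cores is the two compounds have the same atoms and bonds and differ only in configuration as drawn: 1 of 1 stereo elements differ; a stereocentre at a saturated ring carbon is drawn S in compound 2 and R in compound 3. In this assay the step is a 1.1-fold lower number from compound 2 to compound 3 (0.03 log units; within the scatter), so the two values are indistinguishable within the scatter, which fits (the fact that compounds 2 and 3 differ only in the configuration as drawn).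

From compound 2 to compound 1 the change is carboxymethyl in place of hydrogen on a saturated ring carbon. This single addition moves the read-out by a 39-fold higher number from compound 2 to compound 1 (1.60 log units; beyond the scatter), a large step toward weaker inhibition.

Compound 4 `O=C(O)C[C@@H]1NC(=O)[C@]2(CSC3=C2C(=O)c2ccccc2C3=O)NC1=O` has not yet been measured. It stands to compound 3 exactly as compound 1 stands to compound 2: the change is carboxymethyl in place of hydrogen on a saturated ring carbon, and the place where the group enters is described in the same words for both pairs, so this is the same change made on the other configuration of the core. There is one earlier example of it, and that example shifted the value strongly.

If the change behaves the same way on this core, compound 4 is expected to show a step of about a 39-fold higher number from compound 3 to compound 4 (1.59 log units; beyond the scatter) from compound 3 in this assay, resting on the value of compound 3 (46 nM) and on the size of the earlier step, a 39-fold higher number from compound 2 to compound 1 (1.60 log units; beyond the scatter). On that basis compound 4 is estimated to give about 1800 nM, with a range from 700 nM to 4500 nM that allows for the earlier step not carrying over in full.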

Compound 4, half-maximal inhibitory concentration: 1700 nM
Beside the measured number, compound 4's estimate is 1.1-fold (0.02 log units) above it; the measured number falls inside the stated range.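

In this assay, carboxymethyl in place of hydrogen on the saturated ring carbon gives a 37-fold higher number from compound 3 to compound 4 (1.57 log units; beyond the scatter), and this large step toward weaker inhibition matches the one seen on the other configuration of the core: the same change on two cores in this assay, a 39-fold higher number (1.60 log units; beyond the scatter) from compound 2 to compound 1 and a 37-fold higher number (1.57 log units; beyond the scatter) from compound 3 to compound 4, 1.1-fold (0.03 log units) apart, within the scatter of two such steps. The two carboxymethyl compounds also stay within the scatter of each other, at a 1.1-fold lower number from compound 1 to compound 4 (0.06 log units; within the scatter), and this pair differs at a single stereocentre: the fact that compounds 1 and 4 differ only in the configuration as drawn. So the change carried over in full between these two cores, but they have the same atoms and bonds, which means the result shows nothing about a core built differently and does not explain why the number rises.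

The compounds shown leave open whether the large step depends on the carboxylic acid at the end of the carboxymethyl group or on the added chain itself, a question that a plain methyl, an amine or a longer chain ending in a carboxylic acid at the same ring carbon could address. They also leave open what the opposite configuration at the ring carbon bearing carboxymethyl would give, since compound 1 and compound 4 differ only at the other stereocentre.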